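From 4-nitrophenyl to 2-chloro-4-fluorophenyl in a cytotoxicity series

A few compounds are considered here, and "the series" means these few. Any claim that something is new, unique, unknown or untested is made for them only; others in the source may bear on it.

Compounds tested in a functional assay on PC-3 cells (Homo sapiens) for cytotoxicity, read by MTT assay, with a stated time of 72 h; on this read-out higher numbers stand for weaker inhibition and lower numbers for stronger inhibition:
- compound 1 `O=C(N/N=C/c1ccc(F)cc1Cl)Nc1cc2c(Nc3ccc(F)c(Cl)c3)ncnc2cc1O[C@H]1CCOC1`: 28400 nM
- compound 2 `COc1cc2ncnc(Nc3ccc(F)c(Cl)c3)c2cc1NC(=O)N/N=C/c1cccc(Br)c1`: "not active" (no number reported)
- compound 3 `COc1cc2ncnc(Nc3ccc(F)c(Cl)c3)c2cc1NC(=O)N/N=C/c1ccc([N+](=O)[O-])cc1`: 32400 nM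

Only two of these compounds have numbers, and they lie within the usual scatter of each other. In this assay compound 3 gives 32400 nM, level with compound 1 at 28400 nM. Compound 2 was reported without a number, so it cannot be placed beside them.

The next compound to be tested is compound 4 `COc1cc2ncnc(Nc3ccc(F)c(Cl)c3)c2cc1NC(=O)N/N=C/c1ccc(F)cc1Cl`. It has 2-chloro-4-fluorophenyl in place of 4-nitrophenyl on a carbon with a double bond to nitrogen.

Going by the values given here, no step has yet been measured between two compounds that differ in one place, so any expectation rests on thin evidence. Compound 1 also carries the 2-chloro-4-fluorophenyl group and gives 28400 nM, which offers no sign of a large shift. No step beyond the scatter is therefore expected in this assay, in either direction. The expected change is a 1.2-fold lower number from compound 3 to compound 4 (0.08 log units; within the scatter). Compound 2 gave "not active" (no number reported), so a result without a number remains possible for compound 4.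

The estimated value for compound 4 is 27000 nM, with an expected range from 10000 nM to 65000 nM.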

Compound 4, half-maximal inhibitory concentration: 25700 nM
Compound 4: the middle estimate sits 1.1-fold (0.02 log units) above what was measured, and the stated range covers the measured number.
By their numbers in this assay, from the lowest: compounds 4, 1 and 3 (each within the scatter of the next).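

In this assay, going by these compounds alone, the exchange of 4-nitrophenyl for 2-chloro-4-fluorophenyl on a carbon with a double bond to nitrogen gives the first measured single change at this position: a 1.3-fold lower number from compound 3 to compound 4 (0.10 log units; within the scatter). Two quite different aryl groups therefore leave compound 3 and compound 4 level on this read-out, and a second place on the molecule behaves the same way, since methyl in place of oxolan-3-yl on an oxygen on an aromatic ring gives a 1.1-fold lower number from compound 1 to compound 4 (0.04 log units; within the scatter). Nothing available here accounts for why neither change moves the number beyond the scatter.

Compound 2, with its bromine-bearing phenyl group, has no number, so its steps to the other compounds cannot be read, and it remains unclear how it relates to the level values of the other three. From the compounds shown here alone, it also remains open whether an amine or a carboxylic acid on the phenyl ring, or a longer chain ending in an amine on the oxygen now carrying methyl, would shift the number beyond the scatter in this assay.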